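Swapping the Side Chain on the Saturated Ring Carbon

The source may hold more compounds than are shown below. What is called first, only, known or untested is meant among the compounds shown, and "the series" means these compounds.

Among the measured compounds shown here, compound 2 `Cc1nn(-c2ncnc3nc[nH]c23)c2c1C(NC(=O)Cc1cccs1)CC(=O)N2` gives 3 nM in a functional assay on HEK293 cells for agonist activity at G-protein coupled receptor 39 (Homo sapiens), read by scintillation proximity assay and inositol phosphate accumulation, with a stated time of 75 min, in the presence of a further agent that is not named here (a lower number here means that less compound is needed, a higher number that more compound is needed for the effect), the lowest of the two numbers here, while compound 1 `Cc1noc(C)c1COC1CC(=O)Nc2c1c(C)nn2-c1ncnc2nc[nH]c12` gives 5 nM; the only measured step at this position is a 1.7-fold lower number from compound 1 to compound 2 (0.22 log units; within the scatter). Compound 3 `Cc1nn(-c2ncnc3nc[nH]c23)c2c1C(C(=O)N(C)c1nccs1)CC(=O)N2` carries methyl(1,3-thiazol-2-yl)carbamoyl in place of (((thiophen-2-yl)methyl)carbonyl)amino on a saturated ring carbon. The step from compound 1 to compound 2 bears on this change only loosely: it replaced an ether by an amide at the same saturated ring carbon without moving the number beyond the scatter, which hints that this position accepts different side chains. The change to compound 3 differs more in kind, as the entering group has no hydrogen-bond donor where the leaving group had one. For compound 3 a somewhat higher number is therefore expected in this assay, the step being a 2.7-fold higher number from compound 2 to compound 3 (0.43 log units; beyond the scatter). Compound 3 is estimated at 8 nM, in the range 2 nM to 40 nM.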

Compound 3, half-maximal effective concentration: 18 nM
Compound 3: middle estimate off by 2.3-fold (0.35 log units), on the low side, and the stated range covers the measured number.
By their numbers in this assay, from the lowest: compounds 2 and 1 (each within the scatter of the next); then compound 3.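

Among the compounds shown here, the saturated ring carbon is less forgiving than the first pair of compounds suggested, since methyl(1,3-thiazol-2-yl)carbamoyl in place of (((thiophen-2-yl)methyl)carbonyl)amino gives a 6.0-fold higher number from compound 2 to compound 3 (0.78 log units; beyond the scatter) in this assay and this is the first step here to pass beyond the scatter. Set against (3,5-dimethyl-1,2-oxazol-4-yl)methoxy, the same entering group gives a 3.6-fold higher number from compound 1 to compound 3 (0.56 log units; beyond the scatter) so the result holds against both earlier side chains, though both steps are modest. Nothing measured here explains the rise.

The change alters the ring, the amide hydrogen and the direction of the amide all at once, so the compounds shown cannot say which of these matters. Going by these compounds, how a plain amine or a carboxylic acid would fare on this ring carbon also stays open.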